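The Same Swap Applied to a Second Core

The source may report more compounds than this note shows. Statements on the series, on what has been measured and on what is new or still open speak of the compounds shown alone.

Of the compounds shown here, three have been measured so far in a functional assay on B16 cells (Mus musculus) for cytotoxicity, read by MTT assay, with a stated time of 48 h; a lower number here means a stronger inhibitor, a higher number a weaker inhibitor. Compound 1 `C#Cc1cccc(NC(=O)c2cn(Cc3ccccc3)nn2)c1` gives 14500 nM in this assay, and compound 2 `C#Cc1cccc(NC(=O)c2cn(CC(=O)OCC)nn2)c1` gives 91000 nM. The two differ in one place: ethoxycarbonyl in place of phenyl on a saturated chain carbon bound to an aromatic nitrogen. That change produced a 6.3-fold higher number from compound 1 to compound 2 (0.80 log units; beyond the scatter), a modest step that lies beyond the usual scatter.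

Compound 3 `O=C(Cn1cc(C(=O)NCc2cn(Cc3ccccc3)nn2)nn1)OCc1ccccc1` gives 22400 nM in this assay. How its core differs from the core of compound 1 is not broken down here; the values of compound 3 and compound 1 lie within the usual scatter of each other, so no order between them can be read. The value of compound 2 stands higher than that of compound 3 by an amount beyond the scatter.

Compound 4 `CCOC(=O)Cn1cc(CNC(=O)c2cn(CC(=O)OCc3ccccc3)nn2)nn1` has not yet been measured. It differs from compound 3 by ethoxycarbonyl in place of phenyl on a saturated chain carbon bound to an aromatic nitrogen. This is the same change, at the same kind of place, that was made from compound 1 to compound 2, although the core it sits on is different.

Compound 4 is estimated to give 110000 nM in this assay, with the expectation lying between 35000 nM and 350000 nM, because the same change on the other core gave a 6.3-fold higher number from compound 1 to compound 2 (0.80 log units; beyond the scatter). That estimate means an expected step of a 4.9-fold higher number from compound 3 to compound 4 (0.69 log units; beyond the scatter), of roughly the same size as the earlier one, with the wider range reflecting that the change has been seen only once, on a single core.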

Compound 4, half-maximal inhibitory concentration: > 100000 nM
Compound 4: only a limit was reported; the forecaster's own chance of this, stated with the estimate: 25%; the middle value lies beyond the limit too.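

In this assay compound 4 gives > 100000 nM, which is a limit of the assay and not a number. Even so, the change from phenyl to ethoxycarbonyl on a saturated chain carbon bound to an aromatic nitrogen can be read on this second core, where it gives an at least 4.4-fold higher number from compound 3 to compound 4 (0.64 log units; beyond the scatter), so the number moved in the same direction on both cores, towards a weaker inhibitor in each pair. This shows that the direction of the change carried over in the two pairs available, but it does not show that the size carried over, nor does it establish a rule for the series, since it rests on two cores only: the same change on two cores in this assay, a 6.3-fold higher number (0.80 log units; beyond the scatter) from compound 1 to compound 2 and an at least 4.4-fold higher number (0.64 log units; beyond the scatter) from compound 3 to compound 4; the limit leaves it open whether they differ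

The compounds shown leave open whether a carboxylic acid in place of the ethoxycarbonyl, or an amine on the same saturated chain carbon, would move the number in the same direction as the ethoxycarbonyl did. They also leave open whether a longer chain carrying the ester would behave in the same way, and whether the step would keep its direction on a third core.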